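This account rests on a few compounds, and the source may have more. Where it says the series, first, only, none or still open, it means among the compounds named here.

Working notes on the azo series.

In an ADME assay on BHK-21 cells (Mesocricetus auratus) for cytotoxicity, read by MTT assay, with a stated time of 96 h (a lower number here means that less compound is tolerated, a higher number that more compound is tolerated), compound 2 `c1ccc(/N=N/c2ccc(NC[C@@H]3CCCN4CCCC[C@H]34)c3c2CCCC3)cc1` gives only a limit of the assay, > 100000 nM. Compound 1 `Fc1ccc(F)c(/N=N/c2ccc(NC[C@@H]3CCCN4CCCC[C@H]34)c3c2CCCC3)c1` gives 38000 nM in this assay. The change between them is 2,5-difluorophenyl in place of phenyl on a double-bonded nitrogen and it makes a step of an at least 2.6-fold lower number from compound 2 to compound 1 (0.42 log units; beyond the scatter); the step is given as a lower bound because the limit of > 100000 nM in this assay, at which 1 of the 3 values shown sits, is all that is known of compound 2.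

Compound 3 `CN(C)CCCN(/N=N/c1ccccc1)c1cccc(C(F)(F)F)c1` carries a different core; how its core differs from that of compound 2 is not broken down here. In this assay compound 3 gives 49000 nM, and against compound 1 the two values show no separation that the scatter would not cover.

Compound 4 `CN(C)CCCN(/N=N/c1cc(F)ccc1F)c1cccc(C(F)(F)F)c1` is not yet measured in this assay. Its change from compound 3 is 2,5-difluorophenyl in place of phenyl on a double-bonded nitrogen, the same change as before, made at the same kind of place. Going by the values given here, the expected step is a 2.5-fold lower number from compound 3 to compound 4 (0.39 log units; beyond the scatter), resting on an at least 2.6-fold lower number from compound 2 to compound 1 (0.42 log units; beyond the scatter) as the only measured instance of this change, with the caveat that the cores differ. Compound 4 is therefore expected near 20000 nM, most likely between 8000 nM and 50000 nM.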

Compound 4, half-maximal cytotoxic concentration: 54000 nM
Compound 4: the middle estimate sits 2.7-fold (0.43 log units) below what was measured; the whole stated range lies below it.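

In this assay the same change, 2,5-difluorophenyl in place of phenyl on a double-bonded nitrogen, gives a 1.1-fold higher number from compound 3 to compound 4 (0.04 log units; within the scatter). The change therefore does not carry over as a fixed step from one core to the other in this series: the same change on two cores in this assay, an at least 2.6-fold lower number (0.42 log units; beyond the scatter) from compound 2 to compound 1 and a 1.1-fold higher number (0.04 log units; within the scatter) from compound 3 to compound 4, at least 2.9-fold (0.46 log units) apart, beyond the scatter of two such steps. This does not show why the two cores part, and the true size of the earlier step stays open, compound 2 being known only as a limit of the assay: the limit of > 100000 nM in this assay, at which 1 of the 4 values shown sits.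

The compounds shown leave open whether a third core would follow the core of compound 1 or the core of compound 3, and how a single fluorine, a chlorine or a nitrile on the phenyl would read in this assay on either core. Also open, as far as these compounds go, is whether a carboxylic acid in place of the trifluoromethyl, or a longer chain on the core of compound 3, would alter the outcome of the same change.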